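Swapping an Amide Cap for a Urea Cap

The compounds below may be only part of what the source reports. "The series", "measured", "known", "first", "only" and "open" are said of these compounds alone.

Measured so far:
compound 1, `COCC(=O)N1C[C@@H](C)N(c2ncc3[nH]nc(-c4ccc(N5CCN[C@H](C)C5)nc4)c3n2)[C@@H](C)C1`: 7.3 nM
compound 2, `C[C@@H]1CN(c2ccc(-c3n[nH]c4cnc(N5CCCCC5)cc34)cn2)CCN1`: 77 nM
compound 3, `C[C@@H]1CN(c2ccc(-c3n[nH]c4cnc(N5[C@H](C)CCC[C@@H]5C)nc34)cn2)CCN1`: 2.5 nM

Three compounds have numbers in an assay on Sf9 cells for inhibition of activin receptor type-1 (Homo sapiens), read by HTRF, with a stated time of 3 h, in the presence of a further agent that is not named here; on this read-out lower numbers stand for stronger inhibition and higher numbers for weaker inhibition. Compound 1 gives 7.3 nM. Compound 3 gives 2.5 nM, a lower number, and that gap lies beyond the scatter. Compound 2 gives 77 nM, a higher number, and that gap also lies beyond the scatter. Compound 1 therefore stands second highest of the three, closer to compound 3 than to compound 2.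

Compound 4 (`C[C@@H]1CN(c2ccc(-c3n[nH]c4cnc(N5[C@H](C)CN(C(=O)N(C)C)C[C@@H]5C)nc34)cn2)CCN1`) has not yet been measured in this assay. It differs from compound 1 in one place: dimethylamino in place of methoxymethyl on a carbonyl carbon. The carbonyl and the ring nitrogen it sits on stay the same; only the group on the far side of the carbonyl is exchanged. Among the compounds with values here, no pair of measured compounds shows this particular exchange, so there is nothing to lean on beyond the structures themselves. A change of this kind, at the cap of the ring rather than in the shared core, is expected to move the number little. Compound 4 is expected to give about 8 nM, within a range from 2.5 nM to 25 nM. This corresponds to an expected step of a 1.1-fold higher number from compound 1 to compound 4 (0.04 log units; within the scatter), which would sit within the scatter.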

Compound 4, half-maximal inhibitory concentration: 6.4 nM
For compound 4 the middle estimate is 1.3-fold (0.10 log units) above the measured one, and the stated range covers the measured number.
By their numbers in this assay, from the lowest: compound 3; then compounds 4 and 1 (each within the scatter of the next); then compound 2.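

In this assay the move from the (methoxymethyl)carbonyl cap to the dimethylcarbamoyl cap gives a 1.1-fold lower number from compound 1 to compound 4 (0.06 log units; within the scatter) and so the two caps cannot be told apart on this read-out. Within the data shown here, this is the first direct look at this position, since no earlier pair of measured compounds differed only here. It shows that, in this one exchange, a group with the same heavy-atom count but nitrogen in place of oxygen, and with one hydrogen-bond acceptor fewer by the count for the group itself, leaves the number within the usual scatter of repeated measurements; nothing at hand explains why the two caps read alike.

This single pair cannot show how far the position's tolerance extends, and a longer chain such as methoxypropyl, a primary amine or a carboxylic acid on the far side of the carbonyl could behave quite differently. Also open, from the compounds shown here alone, is whether the carbonyl itself matters, which a simple methyl on the ring nitrogen in its place would begin to test.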